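Demethylation of an aryl methoxy group on two related cores

This account rests on a few compounds, and the source may have more. Where it says the series, first, only, none or still open, it means among the compounds named here.

Measured compounds:
compound 1 `COc1ccccc1-c1ccc(Nc2nc(N[C@H]3CC[C@H](N)CC3)nc3c2ncn3C2CCCC2)cc1`: 22800 nM
compound 2 `N[C@H]1CC[C@H](Nc2nc(Nc3ccc(-c4ccccc4O)cc3)c3ncn(C4CCCC4)c3n2)CC1`: 9590 nM
compound 3 `COc1ccccc1-c1ccc(Nc2nc(N[C@H]3CC[C@H](N)CC3)nc3c2ncn3C2CCCC2)cn1`: 6200 nM

In an ADME assay on BJ cells (Homo sapiens) for inhibition, read by fluorescence and resazurin assay, with a stated time of 72 h (a lower number here means a stronger inhibitor of growth, a higher number a weaker inhibitor of growth), compound 1 gives 22800 nM, compound 2 gives 9590 nM and compound 3 gives 6200 nM. Compound 2 differs from compound 1 by hydrogen in place of methyl on an oxygen on an aromatic ring, a change that gave a 2.4-fold lower number from compound 1 to compound 2 (0.38 log units; beyond the scatter). How the core of compound 3 differs from that of compound 1 is not broken down here. Compound 3 and compound 2 lie within the scatter of each other, while compound 3 and compound 1 differ beyond it.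

Compound 4 `N[C@H]1CC[C@H](Nc2nc(Nc3ccc(-c4ccccc4O)nc3)c3ncn(C4CCCC4)c3n2)CC1` differs from compound 3 by hydrogen in place of methyl on an oxygen on an aromatic ring, the same change at the same place as before. For compound 4 a step of similar size is expected, a 2.1-fold lower number from compound 3 to compound 4 (0.32 log units; beyond the scatter). This expectation rests on the earlier instance, which gave a 2.4-fold lower number from compound 1 to compound 2 (0.38 log units; beyond the scatter). Compound 4 is therefore estimated at 3000 nM, most likely between 1500 nM and 7000 nM.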

Compound 4, concentration for 50% growth inhibition: 6350 nM
Compound 4: the middle estimate sits 2.1-fold (0.33 log units) below what was measured, and the stated range covers the measured number.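

In this assay, methoxy to hydroxy on the core of compound 3 gave a 1.0-fold higher number from compound 3 to compound 4 (0.01 log units; within the scatter) and so left no readable step on this core. Set beside the earlier instance, the two steps do not differ beyond what repeated measurement allows: the same change on two cores in this assay, a 2.4-fold lower number (0.38 log units; beyond the scatter) from compound 1 to compound 2 and a 1.0-fold higher number (0.01 log units; within the scatter) from compound 3 to compound 4, 2.4-fold (0.39 log units) apart, within the scatter of two such steps. The change is therefore consistent with carrying over between these two cores, but two pairs neither establish that the earlier modest step transfers nor show that the core alters it.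

The compounds shown leave open how an ethoxy group or an amine in the same place would read on either core. They also leave open whether the hydroxy change would give a readable step on a third core.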